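Swapping the Cyclohexylamino Group of Compound 1 for Phenoxy

The source may report more compounds than this note shows. Statements on the series, on what has been measured and on what is new or still open speak of the compounds shown alone.

Of the compounds shown here, three have been measured in an assay on isolated protein for inhibition of Aromatase (Homo sapiens), read by fluorescence, tested at 1 uM; on this read-out higher numbers stand for more inhibition at the one concentration tested (going by the name of the read-out) and lower numbers for less inhibition. Compound 1, `N#Cc1ccc(Oc2cccnc2)cc1NC1CCCCC1`, gives 33% and stands lowest of the three. Compound 2, `Cc1cc(-n2ccc3ccncc32)ccc1Cl`, gives 96%, and compound 3, `N#Cc1ccc(-n2ccc3ccncc32)cc1`, gives 94%; each of these lies beyond the scatter above compound 1, compound 3 by a smaller margin than compound 2. Compound 2 and compound 3 share no single-point relation with compound 1, so the values alone are what they show.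

Compound 4, `N#Cc1ccc(Oc2cccnc2)cc1Oc1ccccc1`, has not been measured in this assay. It differs from compound 1 in one place: phenoxy in place of cyclohexylamino on an aromatic carbon

Among the compounds with values here, no measured pair isolates this change, so its effect in this assay is unknown. Compound 1 is expected to remain a weak point of reference, and the step from compound 1 to compound 4 is estimated to be a number 7 percentage points higher from compound 1 to compound 4 (within the scatter), a modest rise that may not exceed the scatter. Compound 4 is therefore expected to give about 40% in this assay, within a range from 10% to 75%.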

Compound 4, a percentage reported as inhibition, at one concentration (the size of the read-out at that concentration, not a potency): 78%
For compound 4 the middle estimate is 38 percentage points below the measured one; the measured number lies above the stated range.
By their numbers in this assay, from the lowest: compound 1; then compound 4; then compounds 3 and 2 (each within the scatter of the next).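

Phenoxy in place of cyclohexylamino on this aromatic carbon, ortho to a cyano group and meta to a (pyridin-3-yl)oxy group, gives a number 45 percentage points higher from compound 1 to compound 4 (beyond the scatter) in this assay, the first sign that this position is not indifferent to what it carries. The two groups match in heavy-atom count and each holds a six-membered ring, so the step goes with a change in ring type, linking atom and hydrogen-bond donor count rather than in the number of heavy atoms. Nothing measured here explains the step.

This single pair cannot separate the aromatic ring from the linking atom; phenylamino and cyclohexyloxy would pull the two apart. On these data alone, how a smaller group such as methoxy would read at this position also stays open.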